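The compounds below may be only part of what the source reports. "The series", "measured", "known", "first", "only" and "open" are said of these compounds alone.

Measured so far:
Compound 1, `Cc1nnc(SCC(=O)c2ccc(Cl)cc2)n1N1C(=O)c2ccccc2C1=O`: in a functional assay on PC-3M cells (Homo sapiens) for cytotoxicity, read by MTT assay, with a stated time of 48 h (on this read-out lower numbers stand for stronger inhibition and higher numbers for weaker inhibition), compound 1 gives > 200000 nM, which is a limit of the assay and not a number.
Compound 2, `C#CCSc1nnc(C)n1N1C(=O)c2ccccc2C1=O`: in this assay compound 2 gives > 200000 nM, again a limit rather than a number.

So compound 2 stands only at a limit; its true potency is not known. Within the data shown here, the one measured step, a step that the two limits leave unreadable from compound 1 to compound 2, runs between two limits, and its size cannot be read. the limit of > 200000 nM in this assay, at which 2 of the 2 values shown sit, is the whole of the evidence, and it gives no measured step that bears on the next change.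

Compound 3, `Cc1nnc(SCc2ccccc2Cl)n1N1C(=O)c2ccccc2C1=O`, differs from compound 2 by 2-chlorophenyl in place of ethynyl on a saturated chain carbon bound to a sulfur. With no readable step to lean on, compound 3 is expected to stay near the limit, and the step of an at least 1.3-fold lower number from compound 2 to compound 3 (0.12 log units; that floor lies within the scatter) is expected to be no change that can be told from the scatter. Compound 3 is estimated at 150000 nM, within 30000 nM to 600000 nM.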

Compound 3, half-maximal inhibitory concentration: > 200000 nM
Compound 3: a limit, no number (the forecaster's own chance of this, stated with the estimate: 70%); at least 1.3-fold (0.12 log units) between middle value and limit.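

Among these compounds, no step from compound 1 or compound 2 to compound 3 can be read, since each pair runs between two limits: the limit of > 200000 nM in this assay, at which 3 of the 3 values shown sit. In this assay, as far as these compounds go, the true potency of compound 1, compound 2 and compound 3 stays open, as does whether changing the group on the saturated chain carbon bound to a sulfur alters it at all.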